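A few compounds are considered here, and "the series" means these few. Any claim that something is new, unique, unknown or untested is made for them only; others in the source may bear on it.

In a functional assay on HCT-116 cells (Homo sapiens) for antiproliferative activity, with a stated time of 72 h (on this read-out lower numbers stand for stronger inhibition and higher numbers for weaker inhibition), compound 1 `CC(=O)Oc1cccc(/C=C/c2nc3ccccc3c(=O)[nH]2)c1` gives 9290 nM. Compound 2 `COc1cccc(/C=C/c2nc3ccccc3c(=O)[nH]2)c1` gives > 25000 nM, which is a limit of the assay and not a number. Among the measured compounds shown here, the only measured step, an at least 2.6-fold higher number from compound 1 to compound 2 (0.42 log units; beyond the scatter), does not involve nitro, so it bears only loosely on the next change. Compound 3 `O=c1[nH]c(/C=C/c2cccc([N+](=O)[O-])c2)nc2ccccc12` carries nitro in place of methoxy on an aromatic carbon, with nitro in place of methoxy on an aromatic carbon. For the measured compounds named here, with compound 1 at 9290 nM as the only true number so far, a modest move toward a lower number is expected. The expected step is an at least 1.7-fold lower number from compound 2 to compound 3 (0.25 log units; that floor lies within the scatter). For compound 3 the estimate is 14000 nM, with an expected range of 6000 nM to 25000 nM.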

Compound 3, half-maximal inhibitory concentration: > 25000 nM
Compound 3 gave a limit, no number (the forecaster's own chance of this, stated with the estimate: 40%); at least 1.7-fold (0.25 log units) between middle value and limit.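

In this assay compound 3 gives > 25000 nM as a limit of the assay and not a number. Nitro in place of acetoxy on the aromatic carbon gives an at least 2.6-fold higher number from compound 1 to compound 3 (0.42 log units; beyond the scatter) and so, like methoxy, leaves this position short of the value of compound 1. The step between compound 2 and compound 3 cannot be read: the limit of > 25000 nM in this assay, at which 2 of the 3 values shown sit.

As far as these compounds go, whether a hydroxyl or an amine at this position would give a true number stays open. From the compounds shown here alone, how far nitro and methoxy differ from each other also stays open.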